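This account rests on a few compounds, and the source may have more. Where it says the series, first, only, none or still open, it means among the compounds named here.

Of the compounds shown here, three on the shared core have numbers so far in an ADME assay on microsomes from liver (Homo sapiens) for metabolic stability; a higher number here means faster removal of the compound, a lower number slower removal: compound 1 `CCn1cnc2c(-c3ccnc(Oc4ccccc4)c3)cnnc21` gives 51 mL.min-1.g-1 in this series, compound 2 `CCn1cnc2c(-c3ccc(F)c(Oc4ccc(C#N)cn4)c3)cnnc21` gives 65 mL.min-1.g-1 and compound 3 `CCn1cnc2c(-c3ccc(F)c(-c4ccc(C#N)cc4OC)c3)cnnc21` gives 32 mL.min-1.g-1 on the same scale. Compound 3 and compound 1 lie within the scatter of each other, so no order is drawn between them. Compound 2 has a higher number than compound 3, by a margin just beyond the scatter, which leaves compound 3 in the low part of this small set together with compound 1.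

The next compound is compound 4 `CCn1cnc2c(-c3ccc(F)c(-c4ccc(S(=O)(=O)C5COC5)cc4OC)c3)cnnc21`, which differs from compound 3 in one place: (oxetan-3-yl)sulfonyl in place of cyano on an aromatic carbon, meta to a methoxy group ((oxetan-3-yl)sulfonyl in place of cyano on an aromatic carbon). Among the measured compounds shown here, no two measured compounds differ in only one place, so the series gives no direct measure of this change, and any expectation is loose. A small move toward a lower number is expected (a 1.5-fold lower number from compound 3 to compound 4 (0.16 log units; within the scatter)), within the scatter rather than beyond it. Compound 4 is estimated at 22 mL.min-1.g-1 with 10 mL.min-1.g-1 to 48 mL.min-1.g-1 as the expected range.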

Compound 4, intrinsic clearance in microsomes: 67 mL.min-1.g-1
Compound 4: middle estimate off by 3.0-fold (0.48 log units), on the low side; measured number outside the range, above it.
By their numbers in this assay, from the lowest: compounds 3, 1, 2 and 4 (each within the scatter of the next, the first and the last beyond it).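

At the aromatic carbon meta to a methoxy group and para to a large group, the exchange of cyano for (oxetan-3-yl)sulfonyl gives the series its first direct measure of a single change in this assay, and the result is a 2.1-fold higher number from compound 3 to compound 4 (0.32 log units; beyond the scatter). The step is modest but beyond the scatter and points toward faster removal, so for this one pair the group of 7 heavy atoms, with its four-membered non-aromatic ring and 3 hydrogen-bond acceptors, does not bring the number down from that of the 2-atom cyano group. Substitution at this position therefore registers in this read-out, although a single pair sets no trend, and nothing available on these compounds points to a cause for the step.

The sulfonyl unit and the oxetane ring enter together, so the compounds shown cannot divide the step between them; a plain methylsulfonyl group or a sulfonamide at the same carbon would separate the two parts. Also open, as far as these compounds go, is whether a basic amine or a carboxylic acid at this place would move the number in the same direction, and whether the step carries over to other compounds on the shared core.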